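Methyl added beside the benzothiazole: effect on cell toxicity

A few compounds are considered here, and "the series" means these few. Any claim that something is new, unique, unknown or untested is made for them only; others in the source may bear on it.

Compound 1, `COc1ccc(-c2nc3ccccc3s2)cc1NC(=O)c1cc([N+](=O)[O-])ccc1Cl`: in an ADME assay on HEK293 cells (Homo sapiens) for cytotoxicity, with a stated time of 72 h (on this read-out lower numbers stand for an effect already at smaller amounts and higher numbers for an effect only at larger amounts of compound), compound 1 gives > 25000 nM, which is a limit of the assay rather than a number.
Compound 2, `O=C(Nc1cccc(-c2nc3ccccc3s2)c1)c1cc([N+](=O)[O-])ccc1Cl`: in this assay compound 2 gives > 27000 nM, again a limit of the assay.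
Compound 3, `O=C(Nc1ccc(Cl)c(-c2nc3ccccc3s2)c1)c1cc([N+](=O)[O-])ccc1Cl`: in this assay compound 3 gives > 25000 nM, also a limit.

Compound 2 therefore stands only at a limit, and the two other values shown are limits as well, as the limit of > 25000 nM in this assay, at which 2 of the 3 values shown sit, and the limit of > 27000 nM in this assay, at which 1 of the 3 values shown sits, record. Compound 4, `Cc1c(NC(=O)c2cc([N+](=O)[O-])ccc2Cl)cccc1-c1nc2ccccc2s1`, differs from compound 2 by methyl in place of hydrogen on an aromatic carbon. The measured steps that touch compound 2 are a step that the two limits leave unreadable from compound 1 to compound 2 and a step that the two limits leave unreadable from compound 2 to compound 3, and neither can be read as a size because both ends sit at a limit. Going by the values given here, no step in this set has moved a compound off its limit, so no step beyond the scatter is expected in this assay, in either direction. Compound 4 is expected to give 30000 nM, in a range of 20000 nM to 60000 nM, most likely reported as a limit; this estimate means a step that the limit leaves unreadable from compound 2 to compound 4.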

Compound 4, half-maximal effective concentration: > 25000 nM
Compound 4: only a limit was reported; the forecaster's own chance of this, stated with the estimate: 90%; the middle value lies beyond the limit too.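

Compound 2 and compound 4 both sit at a limit in this assay, so the step between them, methyl in place of hydrogen, cannot be read as a size. The compounds shown leave open at what concentration any of them would reach a half-maximal toxic effect on these cells, and whether methyl changes it.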